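The compounds below may be only part of what the source reports. "The series", "measured", "known", "first", "only" and "open" are said of these compounds alone.

The measured compounds:
- Compound 1 `O=C(Nc1ccnnc1)c1cc(N2C[C@H]3COC[C@H]3C2)ccc1OCc1ccccc1`: in a physicochemical assay for solubility, measured as kinetic solubility (a lower number here means a less soluble compound, a higher number a more soluble compound), compound 1 gives 57000 nM.
- Compound 2 `C[C@@H]1CN(c2ccc(OCc3ccccc3)c(C(=O)Nc3ccnnc3)c2)C[C@H](C)O1`: compound 2 gives 29000 nM.
- Compound 3 `O=C(Nc1ccnnc1)c1cc(N2CCC(O)CC2)ccc1OCc1ccccc1`: compound 3 gives 28000 nM.

Among these three numbers compound 1 holds the highest. Its nearest neighbour is compound 2, a 2.0-fold lower number from compound 1 to compound 2 (0.29 log units; within the scatter), a gap that lies within the usual scatter; the gap to compound 3, a 2.0-fold lower number from compound 1 to compound 3 (0.31 log units; beyond the scatter), is modest but beyond it. Compound 4 `N#CC1CCN(c2ccc(OCc3ccccc3)c(C(=O)Nc3ccnnc3)c2)CC1` has not yet been measured. It differs from compound 1 in one place: a group of 8 heavy atoms (6 carbon, 2 nitrogen; one six-membered non-aromatic ring with 1 hetero atom) in place of a group of 8 heavy atoms (6 carbon, 1 nitrogen, 1 oxygen; 2 five-membered non-aromatic rings with 1 hetero atom each), on an aromatic carbon. Both measured steps bear on this change, since each swaps the same group on the same aromatic carbon for a different six-membered non-aromatic ring, and each gave a somewhat lower number, in one case within the scatter and in the other just beyond it. A similar outcome is expected here: a small decrease, at most modest, quite possibly no larger than the scatter itself. Compound 4 is therefore estimated at 28000 nM, with a likely range from 14000 nM to 57000 nM. This estimate amounts to an expected 2.0-fold lower number from compound 1 to compound 4 (0.31 log units; beyond the scatter), chosen because a 2.0-fold lower number from compound 1 to compound 3 (0.31 log units; beyond the scatter) and a 2.0-fold lower number from compound 1 to compound 2 (0.29 log units; within the scatter) were of about that size.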

Compound 4, solubility: < 1000 nM
Compound 4 was reported as a limit (the forecaster's own chance of this, stated with the estimate: 5%); middle value at least 28-fold (1.44 log units) from the limit.
By their numbers in this assay, from the lowest: compounds 3, 2 and 1 (each within the scatter of the next, the first and the last beyond it). At a limit, below all of these: compound 4.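

In this assay compound 4 gives < 1000 nM, which is a limit of the assay and not a number: the limit of < 1000 nM in this assay, at which 1 of the 4 values shown sits.

Among compounds 1, 2 and 3, swapping the group at this position on the shared core moved the number modestly at most, whereas the new result shows that this position can carry a far larger change: an at least 57-fold lower number from compound 1 to compound 4 (1.75 log units; beyond the scatter), and an at least 29-fold lower number from compound 2 to compound 4 (1.46 log units; beyond the scatter). The sharpest comparison is an at least 28-fold lower number from compound 3 to compound 4 (1.44 log units; beyond the scatter), where only cyano in place of hydroxy on a saturated ring carbon separates the two compounds, so a single substituent on the piperidine ring is enough for a large step. The step from compound 1 also shows that matching counts are no guide here, as the group that leaves and 4-cyanopiperidin-1-yl agree in heavy atoms, hydrogen-bond donors and hydrogen-bond acceptors.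

The compounds shown leave open whether the low number goes with the nitrile itself or with the loss of the hydroxy group. A bare piperidin-1-yl, or a piperidine carrying an amine or a carboxylic acid at the same ring carbon, would help separate these two readings.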